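Trading Methoxyphenyl for Chlorophenyl in an Inactive Series

The source may hold more compounds than are shown below. What is called first, only, known or untested is meant among the compounds shown, and "the series" means these compounds.

Compound 3 `COc1ccc(/C=C2\C(=O)N(c3c(Cl)cccc3Cl)c3ccccc32)cc1` carries a 4-methoxyphenyl group on the double-bonded chain carbon of the shared core. In a functional assay on B16-F10 cells (Homo sapiens) for cytotoxicity against B16-F10 (Mus musculus), read by MTT assay, with a stated time of 72 h (a higher number here means that more compound is needed for the effect, a lower number that less compound is needed), compound 3 gives > 100 ug/mL, which is a limit of the assay rather than a number. Compound 1 `COc1ccc(/C=C2\C(=O)N(c3c(Cl)cccc3Cl)c3ccccc32)cc1OC` gives > 100 ug/mL, also a limit. Compound 2 `O=C1/C(=C\c2c(Cl)cccc2Cl)c2ccccc2N1c1c(Cl)cccc1Cl` gives > 100 ug/mL, a limit as well. The steps a step that the two limits leave unreadable from compound 1 to compound 3 and a step that the two limits leave unreadable from compound 2 to compound 3 therefore cannot be sized, and all that can be said is the limit of > 100 ug/mL in this assay, at which 3 of the 3 values shown sit. Compound 4 `O=C1/C(=C\c2ccccc2Cl)c2ccccc2N1c1c(Cl)cccc1Cl` differs from compound 3 in one place: 2-chlorophenyl in place of 4-methoxyphenyl on a double-bonded chain carbon bound to a double-bonded ring carbon. Going by the values given here, no measured step bears readably on this change. The step of a number no higher from compound 3 to compound 4 (the limit leaves the size open) is expected to be small or none beyond the scatter. Compound 4 is estimated at 100 ug/mL, with a range from 40 ug/mL to 300 ug/mL.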

Compound 4, concentration for half-maximal effect: 39 ug/mL
Estimate against measurement, compound 4: 2.6-fold (0.41 log units) above; the whole stated range lies above it.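

Replacing the 4-methoxyphenyl group on a double-bonded chain carbon bound to a double-bonded ring carbon with 2-chlorophenyl gives an at least 2.5-fold lower number from compound 3 to compound 4 (0.40 log units; beyond the scatter) in this assay. Loss of a single chloro from the 2,6-dichlorophenyl group at the same place gives an at least 2.5-fold lower number from compound 2 to compound 4 (0.40 log units; beyond the scatter), so both changes at this position produce a readable number. Compound 4 alone has a measured number here, the others resting on a limit: the limit of > 100 ug/mL in this assay, at which 3 of the 4 values shown sit.

From the compounds shown here alone, how far compound 2 and compound 3 lie past that limit stays open. So does how an amine or a carboxylic acid in place of this chloro would read.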